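Replacing the thiophene of compound 2 with a bromophenyl group

The source may hold more compounds than are shown below. What is called first, only, known or untested is meant among the compounds shown, and "the series" means these compounds.

Compound 1 `O=Cc1ccc(-c2cn3ccnc3c(-c3ccc4ncn(C5CCCCC5)c4c3)n2)cc1` and compound 2 `c1cn2cc(-c3ccsc3)nc(-c3ccc4ncn(C5CCCCC5)c4c3)c2n1` share one core and differ only in the aryl group on it. Among the measured compounds shown here, in a functional assay on T47D cells (Homo sapiens) for inhibition, read by sulforhodamine B assay, with a stated time of 48 h, tested at 10 uM (a higher number here means more inhibition at the concentration tested (going by the name of the read-out), a lower number less inhibition), compound 1 gives 98%, while compound 2 gives 63.7%, the lowest of the two numbers recorded so far; the only neighbour is compound 1, and the step of a number 34.3 percentage points lower from compound 1 to compound 2 (beyond the scatter) went with thiophen-3-yl in place of 4-formylphenyl on an aromatic carbon.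

Compound 3 `Brc1ccc(-c2cn3ccnc3c(-c3ccc4ncn(C5CCCCC5)c4c3)n2)cc1` is not yet measured. Its change from compound 2 is 4-bromophenyl in place of thiophen-3-yl on an aromatic carbon. For the measured compounds named here, the one measured step that bears on it is the reverse kind of move: leaving a six-membered carbon-only ring for the five-membered sulfur ring cost a large amount in this assay. Going back to a six-membered carbon-only ring, now bearing bromine rather than a formyl group, is therefore expected to recover a good part of that loss, though no measured pair tells how much the substituent on the phenyl ring itself matters.

For compound 3 the expected step is a number 21.3 percentage points higher from compound 2 to compound 3 (beyond the scatter), giving an estimate of 85% with a range from 60% to 99%.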

Compound 3, a percentage reported as inhibition, at one concentration (the size of the read-out at that concentration, not a potency): 55%
For compound 3 the middle estimate is 30 percentage points above the measured one; the whole stated range lies above it.
By their numbers in this assay, from the lowest: compounds 3 and 2 (each within the scatter of the next); then compound 1.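

In this assay the six-membered carbon-only ring alone does not separate the aryl groups at this position: the move is a number 8.7 percentage points lower from compound 2 to compound 3 (within the scatter), so 4-bromophenyl and thiophen-3-yl cannot be told apart here. With the phenyl ring kept, the substituent on it carries a large difference, a number 43 percentage points lower from compound 1 to compound 3 (beyond the scatter), which shows that the high reading of compound 1 goes with the formyl group and not with the phenyl ring as such. No measurement at hand explains why formyl and bromo part so widely.

The compounds shown leave open whether another group in place of formyl on the phenyl ring, such as a nitrile, a carboxylic acid, a hydroxymethyl group or an amine, would keep the reading of compound 1 or fall back to that of compound 3. Read at one concentration, these numbers also leave open how the compounds rank in potency, and whether a formyl group on the thiophen-3-yl ring would raise its reading too.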